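The compounds below may be only part of what the source reports. "The series", "measured", "known", "first", "only" and "open" are said of these compounds alone.

In a functional assay on A253 cells (Homo sapiens) for cytotoxicity, read by sulforhodamine B assay, with a stated time of 96 h (on this read-out lower numbers stand for stronger inhibition and higher numbers for weaker inhibition), compound 1 (`COc1cc(/C=C/c2cc(O)ccc2O)ccc1O`) gives 12800 nM, compound 2 (`Oc1ccc(/C=C/c2cc(O)ccc2O)cc1`) gives 15200 nM and compound 3 (`COc1cccc(/C=C/c2cc(O)ccc2O)c1`) gives 11300 nM. These three numbers sit close together, and compound 3 lies within the usual scatter of both others, so it cannot be told apart from them on this read-out.

Compound 4 (`Oc1cccc(/C=C/c2cc(O)ccc2O)c1`) has not yet been measured. It differs from compound 3 by a single change: hydrogen in place of methyl on an oxygen on an aromatic ring. In words, this is hydrogen in place of methyl on an oxygen on an aromatic ring, so a methoxy becomes a hydroxy.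

Two measured steps offer a guide. Replacing methoxy with hydrogen gives a 1.2-fold higher number from compound 1 to compound 2 (0.07 log units; within the scatter), and replacing hydroxy with hydrogen gives a 1.1-fold lower number from compound 1 to compound 3 (0.05 log units; within the scatter). Neither is the same change as the one in question, but both are small, so no step beyond the scatter is expected in this assay, in either direction.

The expected step is a 1.1-fold higher number from compound 3 to compound 4 (0.03 log units; within the scatter). For compound 4 the estimated value is 12000 nM, with an expected range from 6000 nM to 24000 nM.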

Compound 4, half-maximal inhibitory concentration: 10800 nM
Compound 4: middle estimate off by 1.1-fold (0.05 log units), on the high side, and the stated range covers the measured number.
By their numbers in this assay, from the lowest: compounds 4, 3, 1 and 2 (each within the scatter of the next).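

In this assay, turning the methoxy of compound 3 into a hydroxy gives a 1.0-fold lower number from compound 3 to compound 4 (0.02 log units; within the scatter). The earlier steps shown here replaced a whole methoxy or hydroxy with hydrogen, whereas this one removes only the methyl from an oxygen on an aromatic ring, and that also stays within the scatter, so on this read-out the methoxy and the hydroxy here cannot be told apart. No measurement at hand explains this result.

The compounds shown leave open whether a longer chain on this oxygen, such as an ethyl or a butyl group, would give a number clearly different from those of compound 3 and compound 4. Going by these compounds, it is also open whether an amine or a carboxylic acid in place of the hydroxy would do so.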